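This account rests on a few compounds, and the source may have more. Where it says the series, first, only, none or still open, it means among the compounds named here.

Compound 1 `COc1ccc(-c2nnc(CNc3c(C)n(C)n(-c4ccccc4)c3=O)o2)cc1` gives 2.07 in a physicochemical assay for lipophilicity, measured as octanol-water partition; a higher number here means a more lipophilic compound, a lower number a more polar compound.
Compound 2 `Cc1c(NCc2nnc(-c3ccc(N)cc3)o2)c(=O)n(-c2ccccc2)n1C` gives 1.13.
Compound 3 `Cc1c(NCc2nnc(-c3cccs3)o2)c(=O)n(-c2ccccc2)n1C` gives 1.9.

Compound 2 has the lowest of the three numbers; compound 3 is nearest to it, with a number 0.77 log units higher from compound 2 to compound 3 (beyond the scatter), and compound 1 is furthest. Compound 4 `Cc1c(NCc2nnc(Cc3ccccc3)o2)c(=O)n(-c2ccccc2)n1C` differs from compound 2 in one place: benzyl in place of 4-aminophenyl on an aromatic carbon. Going by the values given here, two measured steps bear on this change. Putting the amino group in place of methoxy gave a number 0.94 log units lower from compound 1 to compound 2 (beyond the scatter), and compound 4 goes the other way, losing that amino group. Replacing the 4-aminophenyl with a different ring gave a number 0.77 log units higher from compound 2 to compound 3 (beyond the scatter). Both point upward by a modest amount, so the expected step for compound 4 is a number 1.07 log units higher from compound 2 to compound 4 (beyond the scatter). Compound 4 is therefore estimated at 2.2, with a likely range from 1.7 to 2.7.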

Compound 4, partition coefficient: 1.64
Estimate against measurement, compound 4: 0.56 log units above, outside the stated range (below it).
By their numbers in this assay, from the lowest: compound 2; then compounds 4, 3 and 1 (each within the scatter of the next, the first and the last beyond it).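

Benzyl on this aromatic carbon sits in the middle of the series in this assay: swapping out 4-aminophenyl gives a number 0.51 log units higher from compound 2 to compound 4 (beyond the scatter), yet swapping out 4-methoxyphenyl gives a number 0.43 log units lower from compound 1 to compound 4 (beyond the scatter). Benzyl and thiophen-2-yl are not separated here, with a number 0.26 log units lower from compound 3 to compound 4 (within the scatter). Nothing measured here accounts for these steps.

Going by these compounds, what a longer chain such as phenethyl, a carboxylic acid or a saturated amine such as piperidine would give in place of benzyl on this carbon stays open.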